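A few compounds are considered here, and "the series" means these few. Any claim that something is new, unique, unknown or untested is made for them only; others in the source may bear on it.

Measured so far:
compound 1 `CCCCCCCCCCCC(=O)OCC(COC(=O)CCCCCCCCCCC)O[C@@H]1O[C@H](CS(=O)(=O)O)[C@@H](O)[C@H](O)[C@H]1O`: 77%
compound 2 `CCCCCCCCCCCC(=O)OCC(CO)O[C@@H]1O[C@H](CS(=O)(=O)O)[C@@H](O)[C@H](O)[C@H]1O`: 31%

In an assay on isolated protein for inhibition of RAC-alpha serine/threonine-protein kinase (Homo sapiens), read by ELISA, tested at 100 uM (a lower number here means less inhibition, a higher number more inhibition at the concentration tested (going by the name of the read-out)), compound 1 stands highest of the two numbers; compound 2 lies beyond the scatter below it. Compound 3 `CCCCCCCCCCCC(=O)OCC(COC(=O)CCCCCCCCCCC)O[C@@H]1O[C@H](CO)[C@@H](O)[C@H](O)[C@H]1O` has not been measured. Its difference from compound 1: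
hydroxy in place of sulfo on a saturated chain carbon bound to a saturated ring carbon
Within the data shown here, no measured pair shows this change, so its size is unknown from the data. A decrease beyond the scatter is expected, with an estimated step of a number 39 percentage points lower from compound 1 to compound 3 (beyond the scatter). Compound 3 is therefore estimated at 38%, in a range from 12% to 65%.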

Compound 3, a percentage reported as inhibition, at one concentration (the size of the read-out at that concentration, not a potency): 7%
Estimate against measurement, compound 3: 31 percentage points above; the whole stated range lies above it.
By their numbers in this assay, from the lowest: compound 3; then compound 2; then compound 1.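

In this assay, sulfomethyl to hydroxymethyl on the core of compound 1 now has a measured size (a number 70 percentage points lower from compound 1 to compound 3 (beyond the scatter)), a large step. With both ester chains kept, inhibition in this pair therefore depends heavily on the sulfo group on a saturated chain carbon bound to a saturated ring carbon, and compound 3 retains only 7% of read-out. No available measurement explains the step.
Open, going by these compounds, is whether a carboxylic acid or a phosphonic acid at this place would match sulfo, or whether an amine would behave like hydroxy. The compounds shown also leave open how a longer chain in the esters would alter the size of this step.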